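Three Inactive Analogues and an Untested Aminophenyl Variant

This account rests on a few compounds, and the source may have more. Where it says the series, first, only, none or still open, it means among the compounds named here.

Compound 3 `Fc1cccc(-c2nc(Nc3cccc(Br)c3)c3cc(F)ccc3n2)c1` is one of three close relatives examined in a functional assay on MCF7 cells (Homo sapiens) for cytotoxicity, read by MTT assay, with a stated time of 48 h; on this read-out lower numbers stand for stronger inhibition and higher numbers for weaker inhibition. In this assay compound 3 gives only a limit, > 50000 nM. Its relative compound 1 `Fc1ccc(Nc2nc(-c3cccc(F)c3)nc3ccc(F)cc23)cc1` likewise gives only a limit in this assay, > 50000 nM. Compound 2 `Fc1cccc(-c2nc(Nc3ccc(Cl)cc3)c3cc(F)ccc3n2)c1` also reaches only a limit in this assay, > 50000 nM. Hence (the limit of > 50000 nM in this assay, at which 3 of the 3 values shown sit), and none of the steps between these three can be sized: a step that the two limits leave unreadable from compound 1 to compound 2, a step that the two limits leave unreadable from compound 1 to compound 3 and a step that the two limits leave unreadable from compound 2 to compound 3 all remain unreadable.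

Compound 4 `Nc1ccccc1Nc1nc(-c2cccc(F)c2)nc2ccc(F)cc12` has not yet been measured. It differs from compound 3 by 2-aminophenyl in place of 3-bromophenyl on a nitrogen on an aromatic ring. Within the data shown here, no measured step involves an aminophenyl group, and every measured step is unreadable, so the existing data give neither a size nor a direction for this change. The step expected here is a step that the limit leaves unreadable from compound 3 to compound 4, which in practice means no movement that could be read against a limit. Compound 4 is therefore expected to give about 60000 nM in this assay, with a range from 20000 nM to 200000 nM, and most likely it will again be reported only as a limit.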

Compound 4, half-maximal inhibitory concentration: > 50000 nM
Compound 4 gave a limit, no number (the forecaster's own chance of this, stated with the estimate: 75%); the middle value is on the limit's open side.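

In this assay compound 4 gives only a limit, > 50000 nM, so its steps from compound 1, compound 2 and compound 3 cannot be read. All four compounds rest at one limit: the limit of > 50000 nM in this assay, at which 4 of the 4 values shown sit.

The compounds shown leave open which structural change, if any, would give a measurable value in this assay.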